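The source may hold more compounds than are shown below. What is called first, only, known or untested is meant among the compounds shown, and "the series" means these compounds.

Three compounds share one core and differ only in the group attached to a carbonyl carbon of the amide. Compound 1 `O=C(Nc1cccc(-c2oc3cc(-c4ccc(F)cc4)ccc3c(=O)c2O)c1)c1ccc(C(F)(F)F)cc1` carries a 4-(trifluoromethyl)phenyl there, and in a functional assay on MDA-MB-231 cells (Homo sapiens) for antiproliferative activity, read by CCK-8 assay, with a stated time of 72 h (on this read-out lower numbers stand for stronger inhibition and higher numbers for weaker inhibition), compound 1 gives 29400 nM. Compound 2 `O=C(Nc1cccc(-c2oc3cc(-c4ccc(F)cc4)ccc3c(=O)c2O)c1)c1cccc(F)c1` carries a 3-fluorophenyl instead; in this assay compound 2 gives 2510 nM, which is a 12-fold lower number from compound 1 to compound 2 (1.07 log units; beyond the scatter). Compound 3 `O=C(Nc1cccc(-c2oc3cc(-c4ccc(F)cc4)ccc3c(=O)c2O)c1)c1ccc(Cl)nc1` carries a 6-chloropyridin-3-yl; in this assay compound 3 gives 1760 nM, which is a 17-fold lower number from compound 1 to compound 3 (1.22 log units; beyond the scatter). Between the two better compounds the gap is small: a 1.4-fold lower number from compound 2 to compound 3 (0.15 log units; within the scatter). Compound 3 thus has the lowest number of the three, but only compound 1 is clearly separated from it.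

Compound 4 `O=C(Nc1cccc(-c2oc3cc(-c4ccc(F)cc4)ccc3c(=O)c2O)c1)c1cc(F)cc(F)c1` is the next step. Its change is 3,5-difluorophenyl in place of 6-chloropyridin-3-yl on a carbonyl carbon. Going by the values given here, the step that bears most directly on it is the one from compound 1 through compound 2, which showed that a small fluorophenyl on the carbonyl carbon already sits far below compound 1, and the step from compound 2 to compound 3 showed that exchanging one such small ring for another moved the number only within the scatter. A second fluorine on the same ring is therefore expected to leave the number near that of compound 2 and compound 3, with no step beyond the scatter: a 1.4-fold higher number from compound 3 to compound 4 (0.15 log units; within the scatter). Compound 4 is estimated at 2500 nM in this assay, with a range from 1000 nM to 6500 nM.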

Compound 4, half-maximal inhibitory concentration: 2440 nM
For compound 4 the middle estimate is 1.0-fold (0.01 log units) above the measured one, within the range that was stated.
By their numbers in this assay, from the lowest: compounds 3, 4 and 2 (each within the scatter of the next); then compound 1.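

Compound 2 and compound 4 differ by a single atom, and in this assay fluoro in place of hydrogen on an aromatic carbon gives a 1.0-fold lower number from compound 2 to compound 4 (0.01 log units; within the scatter) with no readable effect of the second fluorine. Replacing the 6-chloropyridin-3-yl, a ring with a hetero atom, by the 3,5-difluorophenyl, a ring of carbon only, gives a 1.4-fold higher number from compound 3 to compound 4 (0.14 log units; within the scatter) and so no readable difference either. Set against the 4-(trifluoromethyl)phenyl, the same 3,5-difluorophenyl gives a 12-fold lower number from compound 1 to compound 4 (1.08 log units; beyond the scatter) as a clear gap, so compound 2, compound 3 and compound 4 now form a group of three that cannot be told apart, and each stands well clear of compound 1.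

Still open, as far as these compounds go, is whether that gap belongs to the trifluoromethyl group itself or to where it sits on the ring, a question that a 3-(trifluoromethyl)phenyl or a 4-fluorophenyl on the same carbonyl carbon could address, and how an amine or a carboxylic acid on this ring would read. No measurement shown here explains the gap or the flat behaviour of the other three rings.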